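Amide nitrogen substituent swap on a shared anilinopyrimidine core

This account rests on a few compounds, and the source may have more. Where it says the series, first, only, none or still open, it means among the compounds named here.

Measured compounds in a functional assay on DU-145 cells (Homo sapiens) for antiproliferative activity, read by sulforhodamine B assay, with a stated time of 3 days; on this read-out higher numbers stand for weaker inhibition of growth and lower numbers for stronger inhibition of growth:
compound 1, `O=C(NCCO)c1cccc(Nc2ncc(F)c(Nc3ccc(F)cc3)n2)c1`: 13400 nM
compound 2, `Cn1ccnc1NC(=O)c1cccc(Nc2ncc(F)c(Nc3ccc(F)cc3)n2)c1`: 15100 nM
compound 3, `COc1ccc(N2CCN(C)CC2)cc1Nc1ncc(F)c(Nc2ccc(F)cc2)n1`: 910 nM

In this assay compound 2 gives the highest of the three numbers; its nearest neighbour is compound 1, whose value lies within the scatter of it, while compound 3 sits far lower, beyond the scatter. Compound 4, `O=C(Nc1cc(Cl)cc(Cl)c1)c1cccc(Nc2ncc(F)c(Nc3ccc(F)cc3)n2)c1`, is not yet measured. Its difference from compound 2 is 3,5-dichlorophenyl in place of 1-methyl-1H-imidazol-2-yl on an amide-type nitrogen. Going by the values given here, the one measured step on this amide-type nitrogen, a 1.1-fold higher number from compound 1 to compound 2 (0.05 log units; within the scatter), lay within the scatter, so an exchange at this position has so far shifted this assay little. Compound 4 is therefore expected to stay close to compound 2, with perhaps a modest move toward stronger inhibition, the estimated step being a 1.9-fold lower number from compound 2 to compound 4 (0.28 log units; within the scatter). For compound 4 the estimated value is 8000 nM, within a range of 2500 nM to 25000 nM.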

Compound 4, concentration for 50% growth inhibition: 17500 nM
The estimate for compound 4 lay 2.2-fold (0.34 log units) below the measured number; measured number inside the range.
By their numbers in this assay, from the lowest: compound 3; then compounds 1, 2 and 4 (each within the scatter of the next).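

In this assay, 3,5-dichlorophenyl in place of 1-methyl-1H-imidazol-2-yl on the amide-type nitrogen gives a 1.2-fold higher number from compound 2 to compound 4 (0.06 log units; within the scatter), and in place of 2-hydroxyethyl it gives a 1.3-fold higher number from compound 1 to compound 4 (0.12 log units; within the scatter). Going by these compounds alone, the insensitivity seen with the single earlier exchange therefore now holds across three different substituents, including a six-membered aromatic ring of carbon only that carries two chlorines and has no hydrogen-bond acceptors. No supporting data explain this result.

Going by these compounds, it remains open whether a chain ending in an amine, or a carboxylic acid, on this nitrogen would shift the number beyond the scatter.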